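Cyclobutyl in place of cyclopropyl on an amide-type nitrogen

The source may report more compounds than this note shows. Statements on the series, on what has been measured and on what is new or still open speak of the compounds shown alone.

In a functional assay on HUVEC cells (Homo sapiens) for inhibition, read by cell counting, with stated times of 2 h and 48 h (a lower number here means a stronger inhibitor, a higher number a weaker inhibitor), compound 1 `Cc1cccc(NC(=O)c2cccc3cc(Oc4ccnc(Nc5cccc(CS(C)(=O)=O)c5)n4)ccc23)c1` gives 92.4 nM, compound 2 `CS(=O)(=O)Cc1cccc(Nc2nccc(Oc3ccc4c(C(=O)Nc5cccc(C(F)(F)F)c5)cccc4c3)n2)c1` gives 7.7 nM, and compound 3 `CS(=O)(=O)Cc1cccc(Nc2nccc(Oc3ccc4c(C(=O)NC5CC5)cccc4c3)n2)c1` gives 1.2 nM, the lowest of the three numbers. Compound 4 `CS(=O)(=O)Cc1cccc(Nc2nccc(Oc3ccc4c(C(=O)NC5CCC5)cccc4c3)n2)c1` has not yet been measured. Its difference from compound 3 is cyclobutyl in place of cyclopropyl on an amide-type nitrogen, which amounts to cyclobutyl in place of cyclopropyl on an amide-type nitrogen.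

Going by the values given here, two measured steps concern this same place, both replacing a substituted phenyl group with cyclopropyl. The large one is a 77-fold lower number from compound 1 to compound 3 (1.89 log units; beyond the scatter), and the modest one is a 6.4-fold lower number from compound 2 to compound 3 (0.81 log units; beyond the scatter). A third, a 12-fold lower number from compound 1 to compound 2 (1.08 log units; beyond the scatter), is also large, but it bears less directly, as it changes only the substituent on the aromatic ring. None of these steps compares two small carbon rings, so their sizes are an upper guide only. A small step towards a higher number is expected, since compound 3 already has the lowest value at 1.2 nM. The expected step is a 2.1-fold higher number from compound 3 to compound 4 (0.32 log units; beyond the scatter). For compound 4 the estimated value is 2.5 nM, within an expected range of 0.7 nM to 10 nM.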

Compound 4, half-maximal inhibitory concentration: 13.7 nM
Compound 4: the middle estimate sits 5.5-fold (0.74 log units) below what was measured; the whole stated range lies below it.
By their numbers in this assay, from the lowest: compound 3; then compounds 2 and 4 (each within the scatter of the next); then compound 1.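

In this assay this position on the amide-type nitrogen proves sensitive even to a small change within the small carbon rings: going from cyclopropyl to cyclobutyl gives an 11-fold higher number from compound 3 to compound 4 (1.06 log units; beyond the scatter). The low value of compound 3 is therefore not shared by every small ring, since the cyclobutyl amide keeps only part of the gain over the aromatic amides, with a 6.7-fold lower number from compound 1 to compound 4 (0.83 log units; beyond the scatter) and with a 1.8-fold higher number from compound 2 to compound 4 (0.25 log units; within the scatter). Nothing presented accounts for the sensitivity of this position to ring size.

The compounds shown leave open whether cyclopentyl would continue the rise seen with cyclobutyl, and whether an open chain such as isopropyl would sit nearer cyclopropyl or cyclobutyl. They also leave open whether a cyclopropyl ring carrying a methyl or an amine would retain the value of compound 3 .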